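Dropping the Amino Group From Three Inactive Compounds

This account rests on a few compounds, and the source may have more. Where it says the series, first, only, none or still open, it means among the compounds named here.

Compound 1 `CC(CC(C)(C)C)Oc1cccc2ccc(N3CCCCC3)nc12`: in an assay on cells with melanin-concentrating hormone receptor 1 (Homo sapiens) as the target, read by radioligand binding (on this read-out higher numbers stand for weaker inhibition and lower numbers for stronger inhibition), compound 1 gives > 2000 nM, a limit of the assay rather than a number.
Compound 2 `CC(CC(C)(C)C)Oc1cccc2ccc(N3CCCC3)nc12`: in this assay compound 2 gives > 2000 nM, again only a limit.
Compound 3 `CC(CC(C)(C)C)Oc1cccc2ccc(N(C)C)nc12`: in this assay compound 3 gives > 2000 nM, also only a limit.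

Compound 3 therefore stands at a limit, with no numbered value behind it. Compound 4 `CC(CC(C)(C)C)Oc1cccc2cccnc12` differs from compound 3 by hydrogen in place of dimethylamino on an aromatic carbon. The measured steps that bear on this are a step that the two limits leave unreadable from compound 1 to compound 3 and a step that the two limits leave unreadable from compound 2 to compound 3, both unreadable because of the limit of > 2000 nM in this assay, at which 3 of the 3 values shown sit. With every measured value sitting at that limit, no direction can be read for the new step, and compound 4 is expected to remain at or past the same limit, an expected step that the limit leaves unreadable from compound 3 to compound 4. Compound 4 is estimated at 6000 nM, within a range from 1500 nM to 40000 nM.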

Compound 4, half-maximal inhibitory concentration: > 2000 nM
Compound 4: only a limit was reported (the forecaster's own chance of this, stated with the estimate: 85%); the middle value lies beyond the limit too.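

Compound 4 also gives only a limit, so its steps from compound 1, compound 2 and compound 3 cannot be read: the limit of > 2000 nM in this assay, at which 4 of the 4 values shown sit.

The compounds shown leave open whether dropping the amino group changes inhibition at all, in either direction.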